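Dimethoxyphenyl in Place of Dichlorophenyl on a Shared Core

The source may hold more compounds than are shown below. What is called first, only, known or untested is meant among the compounds shown, and "the series" means these compounds.

Three compounds share one core and are followed here. Compound 1 `CCOC(=O)[C@H](CCC(=O)O)NC(=O)c1ccc(CNc2nc3cc(N)cc(N)c3nc2-c2ccccc2)cc1` carries an ester-bearing amide arm on its side chain; in a functional assay on MOLT-4 cells (Homo sapiens) for inhibition, read by sulforhodamine B assay, with a stated time of 48 h (on this read-out lower numbers stand for higher toxicity in this test and higher numbers for lower toxicity in this test), compound 1 gives 34700 nM. Compound 2 `Nc1cc(N)c2nc(-c3ccccc3)c(NCc3ccc(Cl)c(Cl)c3)nc2c1` carries a 3,4-dichlorophenyl on that side instead. In this assay compound 2 gives only a limit, < 100000 nM, which is not a number; this is the limit of < 100000 nM in this assay, at which 1 of the 2 values shown sits. For the measured compounds named here, no step between compound 1 and compound 2 is counted, so their two values simply stand side by side, one a number and one a limit. Compound 3 `COc1ccc(CNc2nc3cc(N)cc(N)c3nc2-c2ccccc2)cc1OC` has not yet been measured. It differs from compound 2 by 3,4-dimethoxyphenyl in place of 3,4-dichlorophenyl on a saturated chain carbon bound to a nitrogen on an aromatic ring. Going by the values given here, no measured step guides this change, so the expected step from compound 2 to compound 3 is a step that the limit leaves unreadable from compound 2 to compound 3, nothing expected beyond the usual scatter. Compound 3 is therefore estimated at 40000 nM, with an expected range from 10000 nM to 100000 nM.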

Compound 3, concentration lethal to 50% of the cells: < 100000 nM
Compound 3: only a limit was reported; the forecaster's own chance of this, stated with the estimate: 35%; the middle value is on the limit's open side.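

In this assay, for the compounds shown here, compound 2 and compound 3 each give only a limit, not a number, so no step between them can be read. The compounds shown leave open how 3,4-dimethoxyphenyl and 3,4-dichlorophenyl compare on this side of the shared core, and where the actual value of either compound lies.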